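A few compounds are considered here, and "the series" means these few. Any claim that something is new, unique, unknown or untested is made for them only; others in the source may bear on it.

Measured in an ADME assay on microsomes from liver (Homo sapiens) for metabolic stability, tested at 2.5 uM; on this read-out higher numbers stand for fast clearance and lower numbers for slow clearance:
compound 1 `COc1cccc(-c2c(S(=O)(=O)c3ccc(OC)c(Cl)c3)cnc3cc(F)ccc23)c1` — 1.71 mL/min
compound 2 `COc1ccc(S(=O)(=O)c2cnc3cc(F)ccc3c2-c2cccc(F)c2)cc1Cl` — 2.08 mL/min

Compound 1 gives the smaller of the two numbers, but compound 2 is only a 1.2-fold higher number from compound 1 to compound 2 (0.09 log units; within the scatter) away, within the scatter. Compound 3 `COc1cccc(-c2c(S(=O)(=O)c3cccc(C#N)c3)cnc3cc(F)ccc23)c1` differs from compound 1 by 3-cyanophenyl in place of 3-chloro-4-methoxyphenyl on a sulfonyl sulfur. Among the compounds with values here, the single measured step concerns fluoro in place of methoxy on an aromatic carbon elsewhere on the shared core; no measured step touches the group on the sulfonyl sulfur. The step of a 1.1-fold lower number from compound 1 to compound 3 (0.06 log units; within the scatter) is therefore expected to be small, with no direction beyond the scatter. Compound 3 is estimated at 1.5 mL/min, range 0.7 mL/min to 3.2 mL/min.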

Compound 3, intrinsic clearance in a liver preparation (reported as CLH), per the amount of preparation that the assay uses: 1.83 mL/min
The estimate for compound 3 lay 1.2-fold (0.09 log units) below the measured number, and the stated range covers the measured number.
By their numbers in this assay, from the lowest: compounds 1, 3 and 2 (each within the scatter of the next).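

In this assay, within the data shown here, the first measured change on the sulfonyl sulfur, 3-cyanophenyl in place of 3-chloro-4-methoxyphenyl, gives a 1.1-fold higher number from compound 1 to compound 3 (0.03 log units; within the scatter), so this read-out does not tell these two groups apart. The step swaps one substituted phenyl for another, and the reading holds only for this pair. No measurement at hand bears on the reason for this result.

Open, as far as these compounds go, is whether a group other than a substituted phenyl on the sulfonyl sulfur, such as an amine or a longer alkyl chain, stays within the scatter of compound 1. Also open, from the compounds shown here alone, is how the chloro, methoxy and nitrile groups each count on their own.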